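This account rests on a few compounds, and the source may have more. Where it says the series, first, only, none or still open, it means among the compounds named here.

In a functional assay on NUGC-3 cells (Homo sapiens) for cytotoxicity, read by sulforhodamine B assay, tested at 10 uM (on this read-out higher numbers stand for more inhibition at the one concentration tested (going by the name of the read-out) and lower numbers for less inhibition), compound 1 `CC(=O)OC[C@H]1O[C@@H](n2cc(-c3cc(-c4ccc(C(C)(C)C)cc4)no3)c(=O)[nH]c2=O)C[C@@H]1OC(C)=O` gives 32.8%, the lowest of the three numbers recorded. Compound 2 `CC(C)(C)c1ccc(-c2cc(-c3cn([C@H]4C[C@H](O)[C@@H](CO)O4)c(=O)[nH]c3=O)on2)cc1` gives 88% in this assay, and compound 3 `CC(=O)OC[C@H]1O[C@@H](n2cc(-c3cn(Cc4ccccc4)nn3)c(=O)[nH]c2=O)C[C@@H]1OC(C)=O` gives 88.7%; both stand beyond the scatter above compound 1. No pair among these three differs in a single place, so no one-step comparison is available from the measured set. Compound 4 `CC(=O)OC[C@H]1O[C@@H](n2cc(-c3cc(-c4ccc(C(C)C)cc4)no3)c(=O)[nH]c2=O)C[C@@H]1OC(C)=O` differs from compound 1 in one way: hydrogen in place of methyl on a saturated chain carbon bound to an aromatic carbon and two saturated chain carbons. Among the measured compounds shown here, no step of this kind has been measured, so the change in this assay is expected to be small, in no direction beyond the scatter, and is estimated as a number 5.2 percentage points higher from compound 1 to compound 4 (within the scatter). Compound 4 is expected to give about 38% in this assay, within a range from 15% to 65%.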

Compound 4, a percentage reported as inhibition, at one concentration (the size of the read-out at that concentration, not a potency): 56.4%
Compound 4: the middle estimate sits 18.4 percentage points below what was measured; low and high end bracket the measured number.
By their numbers in this assay, from the lowest: compound 1; then compound 4; then compounds 2 and 3 (each within the scatter of the next).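

In this assay, among the compounds shown here, the change from 4-(tert-butyl)phenyl to 4-isopropylphenyl gives a number 23.6 percentage points higher from compound 1 to compound 4 (beyond the scatter), the first one-step reading at this position, so losing a single methyl here is enough to move the number beyond the scatter. The data offer no explanation for this step. The compounds shown leave open whether an ethyl or a methyl in place of the isopropyl would carry the rise further. They also leave open whether the same change would move the number at all on compound 2.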